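This account rests on a few compounds, and the source may have more. Where it says the series, first, only, none or still open, it means among the compounds named here.

Of the compounds shown here, three have been measured. Compound 1 `OC[C@H]1O[C@@H](n2cnc3c(NCc4ccc(Cl)cc4)ncnc32)[C@H](O)[C@@H]1O` gives 10200 nM in a functional assay on CCRF-CEM cells (Homo sapiens) for antiproliferative activity, with a stated time of 72 h; on this read-out higher numbers stand for weaker inhibition and lower numbers for stronger inhibition. Compound 2 `OC[C@H]1O[C@@H](n2cnc3c(NCc4ccccc4Br)ncnc32)[C@H](O)[C@@H]1O` gives 12300 nM in this assay. Compound 3 `COc1cccc(CNc2ncnc3c2ncn3[C@@H]2O[C@H](CO)[C@@H](O)[C@H]2O)c1OC` gives only a limit, > 166000 nM, in this assay.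

Compound 3 thus stands at the limit of this assay, as shown by the limit of > 166000 nM in this assay, at which 1 of the 3 values shown sits; the steps leading to it, an at least 16-fold higher number from compound 1 to compound 3 (1.21 log units; beyond the scatter) and an at least 13-fold higher number from compound 2 to compound 3 (1.13 log units; beyond the scatter), are both large, while a 1.2-fold higher number from compound 1 to compound 2 (0.08 log units; within the scatter) is within the scatter. Compound 4 `COc1cccc(CNc2ncnc3c2ncn3[C@@H]2O[C@H](CO)[C@@H](O)[C@H]2O)c1O` differs from compound 3 by hydrogen in place of methyl on an oxygen on an aromatic ring. Among the measured compounds shown here, no measured step alters a methyl on an aromatic oxygen, so none bears directly on this change; the measured steps concern only the aryl group itself. Compound 4 is therefore expected to remain near the limit, with a step of a number no higher from compound 3 to compound 4 (the limit leaves the size open) and an estimated value of 166000 nM, ranging from 40000 nM to 500000 nM.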

Compound 4, half-maximal inhibitory concentration: 300 nM
Estimate against measurement, compound 4: 550-fold (2.74 log units) above; the whole stated range lies above it.
By their numbers in this assay, from the lowest: compound 4; then compounds 1 and 2 (each within the scatter of the next). At a limit, above all of these: compound 3.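

In this assay, methoxy to hydroxy on an oxygen on an aromatic ring gives an at least 550-fold lower number from compound 3 to compound 4 (2.74 log units; beyond the scatter). The value of compound 3 is a limit, not a number: the limit of > 166000 nM in this assay, at which 1 of the 4 values shown sits.

The 2-hydroxy-3-methoxyphenyl group also beats both the 2-bromophenyl and the 4-chlorophenyl groups, with a 41-fold lower number from compound 2 to compound 4 (1.61 log units; beyond the scatter) and a 34-fold lower number from compound 1 to compound 4 (1.53 log units; beyond the scatter), so this single hydroxy, which the earlier aryl steps never touched, separates the lowest number shown from a limit.

The compounds shown leave open whether an amine or a carboxylic acid at this place would serve like the hydroxy. They also leave open what the remaining methoxy contributes.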